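This account rests on a few compounds, and the source may have more. Where it says the series, first, only, none or still open, it means among the compounds named here.

Compound 1 `O=C(NNc1nncc2ccccc12)C1CC1c1ccc(OCC(F)(F)F)cc1` is the starting point of this step. In a functional assay on PC-3 cells (Homo sapiens) for inhibition, read by MTT assay, with a stated time of 72 h (on this read-out higher numbers stand for weaker inhibition and lower numbers for stronger inhibition), compound 1 gives 67000 nM, the highest of the two numbers shown. Compound 2 `O=C(NNC(=O)C1CC1c1ccc(OCC(F)(F)F)cc1)c1ccncc1` gives 44000 nM, which lies within the scatter of the value for compound 1, so the two cannot be ranked. Compound 3 `CC(C)=CCOc1ccc(C2CC2C(=O)NNC(=O)c2ccncc2)cc1` gives only a limit of the assay, > 100000 nM. Going by the values given here, the single measured step, an at least 2.2-fold higher number from compound 2 to compound 3 (0.35 log units; beyond the scatter), concerns a change on the saturated chain carbon bound to the ring oxygen and involves a different pair of compounds, so it does not directly describe the change considered here.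

Compound 4 `O=C(NNc1nncc2ccccc12)C1CC1c1ccc(OC(F)(F)F)cc1` differs from compound 1 by trifluoromethyl in place of 2,2,2-trifluoroethyl on an oxygen on an aromatic ring. Among the compounds with values here, no measured step covers this exchange, and the data give no direction for it. The expectation for this assay is therefore a step no larger than the usual scatter, in no settled direction. Compound 4 is estimated at 67000 nM, with a range from 30000 nM to 150000 nM. That estimate means an expected step of no change at the digits printed from compound 1 to compound 4 (within the scatter).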

Compound 4, half-maximal inhibitory concentration: 92000 nM
Beside the measured number, compound 4's estimate is 1.4-fold (0.14 log units) below it, and the stated range covers the measured number.
By their numbers in this assay, from the lowest: compounds 2, 1 and 4 (each within the scatter of the next, the first and the last beyond it). At a limit, above all of these: compound 3.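

Going from 2,2,2-trifluoroethoxy to trifluoromethoxy on the shared core is the first exchange seen directly at this oxygen on an aromatic ring, and this assay records a 1.4-fold higher number from compound 1 to compound 4 (0.14 log units; within the scatter). The two groups therefore cannot be told apart in this assay, so losing one chain carbon while keeping all the fluorine atoms has no resolved effect here. A larger exchange on the same oxygen, read on a different pair of compounds, did go beyond the scatter, with an at least 2.2-fold higher number from compound 2 to compound 3 (0.35 log units; beyond the scatter).

Compound 3 remains a limit and not a number: the limit of > 100000 nM in this assay, at which 1 of the 4 values shown sits.

Still open, going by these compounds, is whether the trifluoromethyl group would read the same in the setting of compound 2. Also open, on these data alone, is whether a plain methyl or a longer fluorinated chain on this oxygen would give a step beyond the scatter.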